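Replacing the cyclopropylcarbamoyl group of compound 3 with a methylene-linked amine

The compounds below may be only part of what the source reports. "The series", "measured", "known", "first", "only" and "open" are said of these compounds alone.

Measured compounds:
compound 1, `Cc1cc(CCC#N)cc(C)c1Oc1cc(Nc2ccc(C#N)cc2)c(N)cc1C(=O)N(C)C`: 1.08 ug/mL
compound 2, `CCNC(=O)c1cc(N)c(Nc2ccc(C#N)cc2)cc1Oc1c(C)cc(CCC#N)cc1C`: 1.08 ug/mL
compound 3, `Cc1cc(CCC#N)cc(C)c1Oc1cc(Nc2ccc(C#N)cc2)c(N)cc1C(=O)NC1CC1`: 1.94 ug/mL

In a physicochemical assay for solubility, read by HPLC, in phosphate buffer, with a stated time of 4 h, at pH 7.4, tested at 10 mg/mL (a higher number here means a more soluble compound, a lower number a less soluble compound), compound 3 gives the highest of the three numbers, yet its edge is thin: the step of a 1.8-fold higher number from compound 1 to compound 3 (0.25 log units; within the scatter) and the step of a 1.8-fold higher number from compound 2 to compound 3 (0.25 log units; within the scatter) are both within the scatter, and the step of no change at the digits printed from compound 1 to compound 2 (within the scatter) shows no change at all. All three measured compounds therefore sit at essentially the same level in this assay.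

Compound 4, `Cc1cc(CCC#N)cc(C)c1Oc1cc(Nc2ccc(C#N)cc2)c(N)cc1CNC1CC1`, differs from compound 3 in one place: (cyclopropylamino)methyl in place of cyclopropylcarbamoyl on an aromatic carbon. The change removes the carbonyl and its double bond outside aromatic rings, leaving the same count of hydrogen-bond donor and acceptor.

None of the three measured steps bears directly on this change. Each of them swaps only the substituent on the amide-type nitrogen or on the carbonyl carbon, and each stayed within the scatter. For the measured compounds named here, the data give no step that exchanges a carbonyl for a methylene link. For compound 4 the expected step is therefore a 1.3-fold higher number from compound 3 to compound 4 (0.11 log units; within the scatter), an estimate made without a comparable precedent for its size or direction.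

On that basis compound 4 is expected to remain close to the common level of compounds 1 to 3, with the estimate 2.5 ug/mL and a range from 0.6 ug/mL to 10 ug/mL in this assay, the width of the range reflecting the absence of a comparable step.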

Compound 4, solubility: 13.6 ug/mL
Estimate against measurement, compound 4: 5.4-fold (0.74 log units) below, outside the stated range (above it).
By their numbers in this assay, from the lowest: compounds 1, 2 and 3 (each within the scatter of the next); then compound 4.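

For the compounds shown here, at this aromatic carbon, para to a (4-cyanophenyl)amino group, the earlier steps only varied the substituent on the amide and stayed within the scatter, whereas in this assay the exchange of cyclopropylcarbamoyl for (cyclopropylamino)methyl, which removes the carbonyl and keeps the cyclopropyl ring, gives a 7.0-fold higher number from compound 3 to compound 4 (0.85 log units; beyond the scatter). The same exchange measured against the other two amides, with their different substituents, gives a 13-fold higher number from compound 2 to compound 4 (1.10 log units; beyond the scatter) and a 13-fold higher number from compound 1 to compound 4 (1.10 log units; beyond the scatter), so the position responds to the replacement of the carbamoyl link itself in a way that no change on the amide nitrogen had shown among these compounds. Nothing measured here accounts for the size of this step.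

Compound 4 is the only methylene-linked amine shown, so it remains open whether an (ethylamino)methyl or (dimethylamino)methyl group, the counterparts of the amides in compound 2 and compound 1, would give a similar step. Also open, as far as these compounds go, is how a methylene-linked ether or a carboxylic acid at the same aromatic carbon would read, which would separate the loss of the carbonyl from the presence of the amine nitrogen.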